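Moving the Amino Group Around the Ring

A few compounds are considered here, and "the series" means these few. Any claim that something is new, unique, unknown or untested is made for them only; others in the source may bear on it.

The shared core of this short series is the same in every member, and only the group on the saturated chain carbon changes. Compound 1, `Nc1ccc(COc2ccc(OCCOCCNC3CCCC3)cc2)cc1`, is the parent: in a functional assay on SK-OV-3 cells (Homo sapiens) for inhibition, read by CCK-8 assay, with a stated time of 70 h (a lower number here means a stronger inhibitor, a higher number a weaker inhibitor), compound 1 gives 31700 nM. Compound 2, `O=C(O)c1ccc(COc2ccc(OCCOCCNC3CCCC3)cc2)cc1`, carries a carboxy group where compound 1 has its amino group. In this assay compound 2 reaches only the limit of the measurement, > 100000 nM. Among the compounds with values here, the single measured step, an at least 3.1-fold higher number from compound 1 to compound 2 (0.49 log units; beyond the scatter), shows that carboxy in place of amino costs potency, though its true size is unknown because of the limit of > 100000 nM in this assay, at which 1 of the 2 values shown sits.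

Compound 3, `Nc1cccc(COc2ccc(OCCOCCNC3CCCC3)cc2)c1`, is not yet measured. It differs from compound 2 by 3-aminophenyl in place of 4-carboxyphenyl on a saturated chain carbon bound to an oxygen on an aromatic ring. Within the data shown here, this change removes the carboxy group and brings an amino group back, though as 3-aminophenyl rather than in the arrangement found in compound 1, so the only guide is the measured step run in reverse. The expected step is an at least 2.8-fold lower number from compound 2 to compound 3 (0.45 log units; beyond the scatter). Compound 3 is therefore estimated at 35000 nM, within 12000 nM to 100000 nM.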

Compound 3, half-maximal inhibitory concentration: 10800 nM
Compound 3: middle estimate off by 3.2-fold (0.51 log units), on the high side, and the stated range ends above it.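

Within the data shown here, compound 3 gives the first reading at this position that rests on two numbers rather than on a limit. In this assay, 3-aminophenyl in place of 4-aminophenyl gives a 2.9-fold lower number from compound 1 to compound 3 (0.47 log units; beyond the scatter), so where the amino group sits on the ring changes the result even though the group itself stays the same. As far as these compounds go, compound 2 stands only at a limit of the assay, and 3-aminophenyl in place of its 4-carboxyphenyl gives an at least 9.2-fold lower number from compound 2 to compound 3 (0.96 log units; beyond the scatter), a step whose true size stays unknown because it depends on that limit: the limit of > 100000 nM in this assay, at which 1 of the 3 values shown sits. Of the three compounds, compound 3 is the most potent, with its steps to both others beyond the scatter.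

The compounds shown leave open whether a 2-aminophenyl group would extend this trend, and whether a 3-carboxyphenyl group would read differently from 4-carboxyphenyl. They also leave open whether the gain from 3-aminophenyl would hold with other changes to the shared core, such as a longer chain.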